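The source may hold more compounds than are shown below. What is called first, only, known or untested is meant among the compounds shown, and "the series" means these compounds.

Going by the values given here, in a functional assay on MCF7 cells (Homo sapiens) for antiproliferative activity, read by MTT assay, with a stated time of 72 h (on this read-out lower numbers stand for stronger inhibition and higher numbers for weaker inhibition), compound 1 `O=C(N/N=C/c1ccc(F)cc1)Nc1ccc(Oc2ccnc3[nH]ccc23)c(F)c1` gives 800 nM, and it is the only compound in this small set with a number. Compound 2 `O=C(N/N=C/c1cccc([N+](=O)[O-])c1)Nc1ccc(Oc2ccnc3[nH]ccc23)c(F)c1` is recorded as "not active" (no number reported), and compound 3 `O=C(N/N=C/c1ccc(O)cc1)Nc1ccc(Oc2ccnc3[nH]ccc23)c(F)c1` is likewise recorded as "not active" (no number reported). Neither entry offers a figure against which compound 1 can be ranked.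

Compound 4 `O=C(N/N=C/c1ccc(F)cc1)Nc1ccc(Oc2ccnc3[nH]ccc23)cc1` departs from compound 1 in one place: hydrogen in place of fluoro on an aromatic carbon. This puts hydrogen in place of fluoro on an aromatic carbon, ortho to a large group and meta to a large group. Among the compounds with values here, no measured pair isolates this change, so the expectation rests on compound 1 at 800 nM alone. In this assay, no step beyond the usual scatter is expected, with only a slight lean toward weaker inhibition. The entry for compound 3, "not active" (no number reported), shows that a result without a number is also possible here. The estimate means an expected 1.3-fold higher number from compound 1 to compound 4 (0.10 log units; within the scatter). Compound 4 is estimated at 1000 nM, with an expected range from 300 nM to 3500 nM.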

Compound 4, half-maximal inhibitory concentration: 3720 nM
Estimate against measurement, compound 4: 3.7-fold (0.57 log units) below, outside the stated range (above it).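

In this assay, going by these compounds alone, the fluoro on this aromatic carbon, ortho to a large group and meta to a large group, proves not to be a silent passenger: putting hydrogen in its place gives a 4.7-fold higher number from compound 1 to compound 4 (0.67 log units; beyond the scatter) as the first step in this set that can be read as a number. The change is small, with a single fluorine atom leaving and no ring, hydrogen-bond donor, hydrogen-bond acceptor or net charge involved, yet inhibition is clearly weaker without it. Compound 4 nevertheless keeps a measurable value, so removing this fluoro weakens inhibition without abolishing the read-out.

The compounds shown leave open how chloro, methyl or methoxy would fare on this same carbon, and whether the step would hold with another group on the far aromatic ring. What lies behind the step also stays open, as no measurement given here bears on it.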